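Swapping methoxy for fluoro: what growth inhibition to expect

The compounds below may be only part of what the source reports. "The series", "measured", "known", "first", "only" and "open" are said of these compounds alone.

compound 1 `COc1ccc(S(=O)(=O)Nc2cccc(CCc3ccc(C(=O)Nc4ccccc4N)cc3)c2)cc1`: 678 nM
compound 2 `COc1ccc(S(=O)(=O)Nc2ccccc2CCc2ccc(C(=O)Nc3ccccc3N)cc2)cc1`: 23 nM
compound 3 `COc1ccc(S(=O)(=O)Nc2ccccc2CCc2ccc(C(=O)NO)cc2)cc1`: > 10000 nM (a limit, not a number)

In a functional assay on KB cells (Homo sapiens) for antiproliferative activity, read by sulforhodamine B assay, with a stated time of 48 h (on this read-out lower numbers stand for stronger inhibition of growth and higher numbers for weaker inhibition of growth), compound 2 gives 23 nM, the lower of the two actual numbers, with compound 1 at 678 nM. For compound 3 the result of > 10000 nM is a limit of the assay. Compound 4 `Nc1ccccc1NC(=O)c1ccc(CCc2ccccc2NS(=O)(=O)c2ccc(F)cc2)cc1` carries fluoro in place of methoxy on an aromatic carbon, para to a large group (fluoro in place of methoxy on an aromatic carbon). For the measured compounds named here, the only measured step, an at least 430-fold higher number from compound 2 to compound 3 (2.63 log units; beyond the scatter), is large, but it changes a different group, so it gives no direct guide here. Going by the values given here, no measured step touches the methoxy, so only a modest change is expected: a 1.7-fold higher number from compound 2 to compound 4 (0.24 log units; within the scatter), toward a somewhat higher number. The estimate for compound 4 is 40 nM, with an expected range of 10 nM to 160 nM.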

Compound 4, concentration for 50% growth inhibition: 884 nM
For compound 4 the middle estimate is 22-fold (1.34 log units) below the measured one, and the stated range ends below it.
By their numbers in this assay, from the lowest: compound 2; then compounds 1 and 4 (each within the scatter of the next). At a limit, above all of these: compound 3.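

In this assay the methoxy of the 4-methoxyphenyl group proves not to be a neutral spot: fluoro in its place brings a 38-fold higher number from compound 2 to compound 4 (1.58 log units; beyond the scatter) and so much weaker inhibition of growth. The earlier compounds shown here all kept this methoxy, so only now is it clear that growth inhibition responds strongly to a change at this position. Nothing shown here accounts for the size of this loss.

Still open, as far as these compounds go, is whether an amine, a hydroxy or an ethoxy at this place would hold the activity of compound 2. Also open, from the compounds shown here alone, is whether the same swap would matter as much on the core of compound 1.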